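The compounds below may be only part of what the source reports. "The series", "measured", "known", "first", "only" and "open" are said of these compounds alone.

Measured so far in a functional assay on LNCaP cells (Homo sapiens) for antiproliferative activity; on this read-out lower numbers stand for stronger inhibition and higher numbers for weaker inhibition:
- compound 1 `Cn1ncc(Cl)c1-c1cc(C(=O)N[C@@H]2CN[C@H](CCCO)C[C@H]2c2ccc(Cl)c(Cl)c2)oc1Cl`: 210 nM
- compound 2 `CCC[C@@H]1C[C@@H](c2ccc(Cl)c(Cl)c2)[C@H](NC(=O)c2cc(-c3c(Cl)cnn3C)c(Cl)o2)CN1`: "not determined" (no result reported)

Compound 2 has no number to stand on: no result was reported for it, so it cannot be placed against compound 1 and gives no starting value for the next step. The compound to be tested is compound 3 `Cn1ncc(Cl)c1-c1cc(C(=O)N[C@@H]2CN[C@H](CC(=O)NC3CCC3)C[C@H]2c2ccc(Cl)c(Cl)c2)oc1Cl`. The structural change is cyclobutylcarbamoyl in place of ethyl on a saturated chain carbon bound to a saturated ring carbon.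

Among the measured compounds shown here, no measured step between compounds differing in one place is available, so the size of this change in this assay cannot be read from the series. For the measured compounds named here, the only anchor is compound 1 at 210 nM, which shares the core but carries a different side chain. A modest step toward weaker inhibition relative to that value is expected, though this is a low-confidence expectation and a result within the scatter would not be surprising. For compound 3 the estimated value is 300 nM, with an expected range of 80 nM to 1100 nM.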

Compound 3, half-maximal inhibitory concentration: 80 nM
Compound 3: middle estimate off by 3.8-fold (0.57 log units), on the high side, and the stated range covers the measured number.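

In this assay the position on a saturated chain carbon bound to a saturated ring carbon now shows a first readable effect: cyclobutylcarbamoyl in place of 2-hydroxyethyl gives a 2.6-fold lower number from compound 1 to compound 3 (0.42 log units; beyond the scatter) and so moves the read-out toward stronger inhibition. Compound 1 alone could not show that this position accepts a group bearing a four-membered ring and a carbonyl without loss of inhibition, and compound 3 now shows that it does. Compound 2 has no reported result and its step to compound 3 cannot be read, so the ethyl-to-cyclobutylcarbamoyl change itself remains without a size.

No measurement among these data bears on why the number falls.

Open, from the compounds shown here alone, is which part of cyclobutylcarbamoyl carries the step: a plain carbamoyl, an open-chain butylcarbamoyl or a cyclopentylcarbamoyl on the same chain carbon would separate the ring from the amide. Also open, going by these compounds, is how a carboxylic acid or a dimethylamino group at this position would compare with compound 3, since one step on one shared core sets no trend.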